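The source may report more compounds than this note shows. Statements on the series, on what has been measured and on what is new or still open speak of the compounds shown alone.

Series of four lactones, all sharing one core and differing in a pendant aryl group. Compound 1 `Cc1ccccc1C[C@H]1C(=O)OC[C@@H]1Cc1ccccc1` gives, in a functional assay on HL-60 cells (Homo sapiens) for cytotoxicity, read by WST assay, with a stated time of 48 h (on this read-out lower numbers stand for an effect already at smaller amounts and higher numbers for an effect only at larger amounts of compound), 57000 nM. Compound 2 `O=C1OC[C@H](Cc2ccccc2)[C@H]1Cc1ccccc1C(F)(F)F` carries trifluoromethyl in place of methyl on an aromatic carbon and gives 37000 nM; the step is a 1.5-fold lower number from compound 1 to compound 2 (0.19 log units; within the scatter). Compound 3 `Cc1ccc(C[C@H]2C(=O)OC[C@@H]2Cc2ccccc2)cc1` differs from compound 1 by 4-methylphenyl in place of 2-methylphenyl on a saturated chain carbon bound to a saturated ring carbon, and in this assay compound 3 gives 44000 nM; the step is a 1.3-fold lower number from compound 1 to compound 3 (0.11 log units; within the scatter). Compound 2 and compound 3 lie within the scatter of each other.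

Compound 4 `O=C1OC[C@H](Cc2ccccc2)[C@H]1Cc1ccc(C(F)(F)F)cc1` is not yet measured. It differs from compound 3 by trifluoromethyl in place of methyl on an aromatic carbon. The same kind of change is already seen from compound 1 to compound 2, where the trifluoromethyl sits ortho to a large group, whereas in compound 4 it sits para to a large group. The earlier step was a 1.5-fold lower number from compound 1 to compound 2 (0.19 log units; within the scatter), within the scatter. Within the data shown here, from compound 3 to compound 4 a step of about a 1.4-fold lower number from compound 3 to compound 4 (0.14 log units; within the scatter) is expected, resting on that single earlier step and on the narrow spread of the three numbers so far. Compound 4 is therefore estimated at 32000 nM, with a range of 15000 nM to 70000 nM.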

Compound 4, half-maximal effective concentration: 22000 nM
Compound 4: the middle estimate sits 1.5-fold (0.16 log units) above what was measured; the range from low to high includes it.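

In this assay the new case of trifluoromethyl in place of methyl, para to a large group, is a 2.0-fold lower number from compound 3 to compound 4 (0.30 log units; within the scatter), and it does not differ from the earlier case of the same change: the same change on two cores in this assay, a 1.5-fold lower number (0.19 log units; within the scatter) from compound 1 to compound 2 and a 2.0-fold lower number (0.30 log units; within the scatter) from compound 3 to compound 4, 1.3-fold (0.11 log units) apart, within the scatter of two such steps

As far as two pairs can show, the change carries from the core of compound 1 to the core of compound 3 with no sign that the two respond differently, even though the group sits in a different place on the aromatic ring. Both steps lie within the scatter, however, so neither pair establishes that the change has a real effect on the number, and two pairs make no rule for the series.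

Still open, on these data alone, is whether another group on this ring, such as an amine, a carboxylic acid or a nitrile, would move the number beyond the scatter. Also open, as far as these compounds go, is what any such group would do on the second aromatic ring, which carries no substituent in all four compounds.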